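Vinyl sulfone series: side-chain change on the ring nitrogen

The source may hold more compounds than are shown below. What is called first, only, known or untested is meant among the compounds shown, and "the series" means these compounds.

In a functional assay on K562 cells (Homo sapiens) for cytotoxicity, read by trypan blue exclusion, with a stated time of 96 h (a lower number here means a stronger inhibitor, a higher number a weaker inhibitor), compound 1 `COc1ccc(CS(=O)(=O)/C=C/c2c(OC)cccc2OC)c([N+](=O)[O-])c1` gives 50000 nM. Compound 2 `COC(=O)CCNc1cc(CS(=O)(=O)/C=C/c2c(OC)cc(OC)cc2OC)ccc1OC` gives 1000 nM, the lowest of the two numbers, and its gap to compound 1 lies beyond the scatter. Compound 3 `COC(=O)C(Nc1cc(CS(=O)(=O)/C=C/c2c(OC)cc(OC)cc2OC)ccc1OC)c1ccc(Br)cc1` carries (4-bromophenyl)(methoxycarbonyl)methyl in place of 2-(methoxycarbonyl)ethyl on a nitrogen on an aromatic ring. Among the compounds with values here, no pair of measured compounds covers this change, so the two values give no direction for it. The step of no change at the digits printed from compound 2 to compound 3 (within the scatter) is expected to be none beyond the scatter. Compound 3 is therefore expected to give 1000 nM, with a range from 300 nM to 3500 nM.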

Compound 3, half-maximal inhibitory concentration: 200 nM
The estimate for compound 3 lay 5.0-fold (0.70 log units) above the measured number; the measured number lies below the stated range.
By their numbers in this assay, from the lowest: compound 3; then compound 2; then compound 1.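

At the nitrogen on an aromatic ring, the side chain matters in this assay: (4-bromophenyl)(methoxycarbonyl)methyl in place of 2-(methoxycarbonyl)ethyl goes with a 5.0-fold lower number from compound 2 to compound 3 (0.70 log units; beyond the scatter). The position thus accepts the entering group of 12 heavy atoms, with its six-membered aromatic ring and bromine, without a loss in this read-out. Nothing at hand explains the step.

The compounds shown do not separate the contributions of the aromatic ring and the bromine. On these data alone, how a plain phenyl in place of 4-bromophenyl, or a carboxylic acid in place of the methyl ester, would read remains open.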